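Replacing nitro with hydrogen: compound 3 to compound 4

The source may hold more compounds than are shown below. What is called first, only, known or untested is meant among the compounds shown, and "the series" means these compounds.

In an ADME assay on HEL cells (Homo sapiens) for cytotoxicity (on this read-out lower numbers stand for higher toxicity in this test and higher numbers for lower toxicity in this test), compound 1 `O=C(COc1cccc2ccccc12)N/N=C/c1ccc(O)cc1` gives 60.6 ug/mL while compound 2 `O=C(COc1cccc2ccccc12)N/N=C/C=C/c1ccccc1` gives 100 ug/mL and compound 3 `O=C(COc1cccc2ccccc12)N/N=C/c1cccc([N+](=O)[O-])c1` gives 61.2 ug/mL in this read-out. Compound 3 lies within the scatter of both other compounds, so no order can be drawn among the three numbers.

Compound 4 `O=C(COc1cccc2ccccc12)N/N=C/c1ccccc1` differs from compound 3 by a single change, hydrogen in place of nitro on an aromatic carbon. Going by the values given here, no measured pair isolates this change. Among the compounds with values here, the one measured step, a 1.7-fold higher number from compound 1 to compound 2 (0.22 log units; within the scatter) at a carbon with a double bond to nitrogen, concerns a different group and stays within the scatter. Compound 1 with its 4-hydroxyphenyl and compound 3 with its nitro also show no separation. Given the step of a 1.7-fold higher number from compound 1 to compound 2 (0.22 log units; within the scatter) as the only measured size, no step beyond the scatter is expected in this assay and no direction is favoured. The estimated change is a 1.1-fold higher number from compound 3 to compound 4 (0.03 log units; within the scatter) and it stays within the scatter. Compound 4 is expected at 65 ug/mL with a range from 35 ug/mL to 110 ug/mL in this estimate.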

Compound 4, half-maximal cytotoxic concentration: 64.5 ug/mL
Estimate against measurement, compound 4: 1.0-fold (0.00 log units) above; measured number inside the range.
By their numbers in this assay, from the lowest: compounds 1, 3, 4 and 2 (each within the scatter of the next).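

In this assay, going by these compounds alone, the step of a 1.1-fold higher number from compound 3 to compound 4 (0.02 log units; within the scatter) is the first direct reading of this change, on an aromatic carbon of a six-membered aromatic ring of carbon only, meta to a large group: the read-out does not separate hydrogen from nitro, although nitro brings 3 heavy atoms and 2 hydrogen-bond acceptors that hydrogen lacks. Compound 4 also gives the series a reference without a ring substituent, and the step of a 1.1-fold higher number from compound 1 to compound 4 (0.03 log units; within the scatter) shows that exchanging the hydroxy group for hydrogen likewise stays within the scatter. The step of a 1.6-fold lower number from compound 2 to compound 4 (0.19 log units; within the scatter) extends this to phenyl in place of 2-phenylethenyl on the carbon with a double bond to nitrogen, so none of the three changes read against compound 4 gives a separation in this assay.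

On these data alone, whether an amine or a carboxylic acid on this aromatic carbon, or a longer chain on the carbon with a double bond to nitrogen, would give a step beyond the scatter remains open. No supporting data accompany these results to explain why the compared groups read alike.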